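The source may report more compounds than this note shows. Statements on the series, on what has been measured and on what is new or still open speak of the compounds shown alone.

In a functional assay on K562/Adr cells (Homo sapiens) for inhibition, read by MTT assay, with a stated time of 48 h (a higher number here means a weaker inhibitor, a lower number a stronger inhibitor), compound 1 (`C=CC(=O)Nc1ccc(-c2cn([C@@H]3CN[C@H](C(=O)Nc4ccc(Cl)c(C(F)(F)F)c4)C3)nn2)cn1`) gives 80400 nM. Compound 3 (`CC(C)(C)OC(=O)N1C[C@@H](n2cc(-c3ccc4nc(N)sc4n3)nn2)C[C@H]1C(=O)Nc1ccc(F)c(F)c1`) gives 63900 nM, which lies within the scatter of that number. Compound 2 (`CC(=O)Nc1n[nH]c2cc(-c3cn([C@@H]4CN[C@H](C(=O)Nc5ccc(Br)cc5)C4)nn3)ccc12`) gives 1000 nM, a far lower number than that of compound 1.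

Compound 4 (`Nc1nc2ccc(-c3cn([C@@H]4CN[C@H](C(=O)Nc5ccc(Cl)c(C(F)(F)F)c5)C4)nn3)nc2s1`) keeps the core of compound 1 but loses the 6-((vinylcarbonyl)amino)pyridin-3-yl group: a group of 10 heavy atoms (6 carbon, 3 nitrogen, 1 sulfur; one five-membered aromatic ring with 2 hetero atoms, one six-membered aromatic ring with 1 hetero atom) in place of a group of 11 heavy atoms (8 carbon, 2 nitrogen, 1 oxygen; one six-membered aromatic ring with 1 hetero atom), on an aromatic carbon. Among the measured compounds shown here, no measured pair shows this change alone. The entering group also stands on compound 3, which differs elsewhere and gives 63900 nM, so no step beyond the scatter is expected. The estimated change is a 1.8-fold lower number from compound 1 to compound 4 (0.25 log units; within the scatter). Compound 4 is expected near 45000 nM, with an estimated range of 9000 nM to 120000 nM.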

Compound 4, half-maximal inhibitory concentration: 187000 nM
Estimate against measurement, compound 4: 4.2-fold (0.62 log units) below, and the stated range ends below it.
By their numbers in this assay, from the lowest: compound 2; then compounds 3 and 1 (each within the scatter of the next); then compound 4.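

Within this assay, putting the two-ring group of compound 4 in place of the 6-((vinylcarbonyl)amino)pyridin-3-yl group gives a 2.3-fold higher number from compound 1 to compound 4 (0.37 log units; beyond the scatter) on an otherwise unchanged molecule. Among the compounds shown here, this is the first measured step at this position, and it shows that the number responds, modestly, to the group held there. No measurement shown here accounts for the step. From the compounds shown here alone, it remains open how a much smaller group, such as a plain amine or a single methyl, would read at this position. Going by these compounds, whether the same swap gives a similar step with a different amide group also remains open.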